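Swapping a Methoxyphenyl Group for Pyridyl on a Shared Core

The compounds below may be only part of what the source reports. "The series", "measured", "known", "first", "only" and "open" are said of these compounds alone.

Of the compounds shown here, three with a common core have been tested in a functional assay on BV-2 cells (Mus musculus) for inhibition, read by ELISA, with a stated time of 16 h; a lower number here means a stronger inhibitor, a higher number a weaker inhibitor. Compound 1 `Cc1cc(Cl)nnc1N1CCN(c2ncccn2)CC1` is reported only as a limit, > 100000 nM, not as a number. Compound 2 `Cc1ccnnc1N1CCN(c2ncccn2)CC1` is likewise reported only as a limit, > 100000 nM. Among the measured compounds shown here, compound 3 `COc1ccc(-c2cc(C)c(N3CCN(c4ncccn4)CC3)nn2)cc1` gives 5200 nM in this assay, the single number in the set; the other two entries are the limit of > 100000 nM in this assay, at which 2 of the 3 values shown sit. Putting a 4-methoxyphenyl group onto the core produced an at least 19-fold lower number from compound 1 to compound 3 (1.28 log units; beyond the scatter) and an at least 19-fold lower number from compound 2 to compound 3 (1.28 log units; beyond the scatter).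

Compound 4 `Cc1cc(-c2ccncc2)nnc1N1CCN(c2ncccn2)CC1` differs from compound 3 by pyridin-4-yl in place of 4-methoxyphenyl on an aromatic carbon. For the measured compounds named here, no measured step exchanges one aromatic group for another; the two large steps show only that an aromatic group at this position brings the number down from the limit. Pyridin-4-yl keeps one six-membered aromatic ring and one hydrogen-bond acceptor at the same place, so the expected step is a 1.5-fold higher number from compound 3 to compound 4 (0.19 log units; within the scatter). Compound 4 is therefore estimated at about 8000 nM, with a range from 2000 nM to 40000 nM.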

Compound 4, half-maximal inhibitory concentration: > 100000 nM
Compound 4 was reported as a limit; the forecaster's own chance of this, stated with the estimate: 15%; middle value at least 12-fold (1.09 log units) from the limit.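

Having an aromatic ring at this position is not enough on its own: in this assay, the swap gives an at least 19-fold higher number from compound 3 to compound 4 (1.28 log units; beyond the scatter), although the entering and leaving groups each carry one six-membered aromatic ring and one hydrogen-bond acceptor. Among the compounds shown here, the earlier compounds showed only that 4-methoxyphenyl brings the number down compared with chloro or hydrogen, whereas this swap shows that the identity of the aromatic group matters, since pyridin-4-yl does not share that gain. The steps to compound 4 from compound 1 and compound 2 cannot be read, as both ends are limits, which leaves compound 3 alone with a true number: the limit of > 100000 nM in this assay, at which 3 of the 4 values shown sit.

The compounds shown leave open whether the loss goes with the ring nitrogen of pyridin-4-yl or with the missing methoxy group, a question a plain phenyl group would help separate. They also leave open how a pyridin-3-yl or 4-chlorophenyl group would read here.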